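This account rests on a few compounds, and the source may have more. Where it says the series, first, only, none or still open, it means among the compounds named here.

Measured so far in an ADME assay on the whole organism (strain Sprague-Dawley) for metabolic stability, with Rattus norvegicus as the target; a lower number here means that the compound disappears faster, a higher number that the compound lasts longer:
- compound 1 `Nc1nc2c(s1)CCC[C@H]2C(=O)Nc1ccc(C[C@@H]2CC[C@H]([C@H](O)c3ccccc3)N2)cc1`: 3 h
- compound 2 `Cc1nc2c(s1)CC[C@H]2C(=O)Nc1ccc(C[C@@H]2CC[C@H]([C@H](O)c3ccccc3)N2)cc1`: 1 h

Of these two compounds, compound 2 holds the lower number, 1 h, while compound 1 reaches 3 h. The next compound, compound 3 `Nc1nc2c(s1)CC[C@H]2C(=O)Nc1ccc(C[C@@H]2CC[C@H]([C@H](O)c3ccccc3)N2)cc1`, departs from compound 2 at one place, with amino in place of methyl on an aromatic carbon. Among the measured compounds shown here, only one measured step bears on this change, a 3.0-fold lower number from compound 1 to compound 2 (0.48 log units; beyond the scatter), which is modest. That step replaces the whole group on the carbonyl carbon, so it combines amino going to methyl with a six-membered non-aromatic ring of carbon only going to a five-membered one. For the measured compounds named here, compound 3 keeps the amino of compound 1 but the five-membered ring of compound 2, and no measured pair isolates the amino change. A small upward step in this assay is therefore expected, smaller than the full size of a 3.0-fold lower number from compound 1 to compound 2 (0.48 log units; beyond the scatter). The estimated step is a 1.8-fold higher number from compound 2 to compound 3 (0.26 log units; within the scatter). For compound 3 the expected half-life is 1.8 h, with an estimated range of 0.9 h to 3.5 h.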

Compound 3, half-life: 4 h
Estimate against measurement, compound 3: 2.2-fold (0.35 log units) below, outside the stated range (above it).
By their numbers in this assay, from the lowest: compound 2; then compounds 1 and 3 (each within the scatter of the next).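

In this assay, the amino in place of methyl on this aromatic carbon, next to the ring nitrogen and next to the ring sulfur, can now be read on its own: with the five-membered non-aromatic ring held constant, it gives a 4.0-fold higher number from compound 2 to compound 3 (0.60 log units; beyond the scatter) and lies beyond the scatter. The earlier step, a 3.0-fold lower number from compound 1 to compound 2 (0.48 log units; beyond the scatter), combined this change with a change of ring size, and the new pair separates the two: with amino held in place, going from the six-membered to the five-membered ring gives a 1.3-fold higher number from compound 1 to compound 3 (0.12 log units; within the scatter), which lies within the scatter, so among these three compounds the difference follows the amino and methyl groups rather than the ring size. Nothing measured here explains why the amino group has this effect.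

The compounds shown leave open how a methylamino group, a hydroxyl group or a plain hydrogen would behave on this aromatic carbon. They also leave open whether the amino-for-methyl step holds on the six-membered ring, since only the five-membered ring carries both groups here.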